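The source may report more compounds than this note shows. Statements on the series, on what has been measured and on what is new or still open speak of the compounds shown alone.

Measured so far:
- compound 1, `C[S+]([O-])/C=C/C(=O)NC1CCCN1C(=O)/C=C/c1ccccc1`: in a functional assay on MCF7 cells (Homo sapiens) for cytotoxicity (a higher number here means that more compound is needed for the effect, a lower number that less compound is needed), compound 1 gives > 5 ug/mL, a limit of the assay rather than a number.
- compound 2, `COC1CCCN1C(=O)/C=C/c1ccccc1`: in this assay compound 2 gives > 5 ug/mL, likewise a limit.

Compound 2 therefore stands only on a limit; no concentration for half-maximal effect is known for it. For the measured compounds named here, the one further value shown is a limit too, so both measured values sit at the same edge of the assay (the limit of > 5 ug/mL in this assay, at which 2 of the 2 values shown sit). Going by the values given here, no step between measured compounds can be sized from this.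

Compound 3, `CS/C=C/C(=O)NC1CCCN1C(=O)/C=C/c1ccccc1`, is the next one to be tested. It differs from compound 2 as follows: ((2-(methylsulfanyl)ethenyl)carbonyl)amino in place of methoxy on a saturated ring carbon. Compound 1, which carries a related chain at the same place, also sits at the limit, so the chain by itself has not yet brought a measurable number in this assay.

Expectation: no step beyond the usual scatter, with compound 3 most likely ending at or near the limit again; the estimated step that the limit leaves unreadable from compound 2 to compound 3 is small. Compound 3 is estimated at 8 ug/mL, within 2 ug/mL to 30 ug/mL, with a fair chance that only a limit is reported.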

Compound 3, concentration for half-maximal effect: > 5 ug/mL
Compound 3 gave a limit, no number (the forecaster's own chance of this, stated with the estimate: 65%); the middle value lies beyond the limit too.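

In this assay compound 3 gives > 5 ug/mL, a limit and not a number. The steps from compound 1 and compound 2 to compound 3 therefore cannot be read: the limit of > 5 ug/mL in this assay, at which 3 of the 3 values shown sit.

The compounds shown leave open the actual concentration for half-maximal effect of compound 1, compound 2 and compound 3, and whether the ((2-(methylsulfanyl)ethenyl)carbonyl)amino group changes it.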